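Methoxy in place of hydrogen across two acylhydrazide cores

This account rests on a few compounds, and the source may have more. Where it says the series, first, only, none or still open, it means among the compounds named here.

Compound 1 `O=C(/C=C/c1ccc(O)cc1)NNC(=O)c1ccccc1` is the reference for this series; in an ADME assay on NL20 cells (Homo sapiens) for antiproliferative activity, read by MTT assay, with a stated time of 24 h (a lower number here means a stronger inhibitor, a higher number a weaker inhibitor), compound 1 gives 9750 nM. Compound 2 `COc1ccc(C(=O)NNC(=O)/C=C/c2ccc(O)cc2)cc1` carries methoxy in place of hydrogen on an aromatic carbon. In this assay compound 2 reaches only a limit of the assay, > 10000 nM. The measured step is therefore an at least 1.0-fold higher number from compound 1 to compound 2 (0.01 log units; that floor lies within the scatter), and its size is set by the limit of > 10000 nM in this assay, at which 2 of the 3 values shown sit, rather than by a number, so it gives a floor only.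

Compound 3 `COc1cc(/C=C/C(=O)NNC(=O)c2ccccc2)cc(OC)c1O` is the second core; the difference between the two cores is not broken down here. In this assay compound 3 likewise gives only a limit, > 10000 nM.

Compound 4 `COc1ccc(C(=O)NNC(=O)/C=C/c2cc(OC)c(O)c(OC)c2)cc1` is not yet measured; it differs from compound 3 by methoxy in place of hydrogen on an aromatic carbon. The place is the same as in the change from compound 1 to compound 2, so it is the same change. Compound 3 already sits at the limit, and the parallel step was a floor, so no gain is expected from compound 3 to compound 4: the step is expected to be a step that the limit leaves unreadable from compound 3 to compound 4. Compound 4 is expected at 16000 nM, between 8000 nM and 40000 nM, most likely again as a limit.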

Compound 4, half-maximal inhibitory concentration: 9420 nM
For compound 4 the middle estimate is 1.7-fold (0.23 log units) above the measured one, within the range that was stated.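

In this assay the change from phenyl to 4-methoxyphenyl on the second core gives an at least 1.0-fold lower number from compound 3 to compound 4 (0.02 log units; that floor lies within the scatter). Compound 3 gives > 10000 nM, which is a limit of the assay and not a number, so this step, like the one on the first core, is a floor only and has no measured size. Carrying the change from one core to the other thus shows no step beyond the scatter on either core, and it does not show whether the change behaves alike or differently on the two: the same change on two cores in this assay, an at least 1.0-fold higher number (0.01 log units; that floor lies within the scatter) from compound 1 to compound 2 and an at least 1.0-fold lower number (0.02 log units; that floor lies within the scatter) from compound 3 to compound 4; the limit leaves it open whether they differ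

Going by these compounds, how large the change is on either core stays open, as some of the values are limits rather than numbers: the limit of > 10000 nM in this assay, at which 2 of the 4 values shown sit. Also open is whether another group on that aromatic carbon, such as an amine, a carboxylic acid or a longer alkoxy chain, would give values that can be read on both cores.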